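Removing the Guanidine from a Phenylurea 5-HT3 Ligand

A few compounds are considered here, and "the series" means these few. Any claim that something is new, unique, unknown or untested is made for them only; others in the source may bear on it.

Measured compounds:
compound 1, `N=C(N)NC(=N)Nc1ccccc1Cl`, 62 nM
compound 2, `Cc1cccc(NC(=N)N=C(N)N)c1`, 780 nM
compound 3, `N=C(N)NC(=O)Nc1cccc(Cl)c1`, 1250 nM

In an in vitro assay on NG 108-15 cells for binding affinity to Serotonin 3 (5-HT3) receptor (Homo sapiens) (on this read-out lower numbers stand for stronger inhibition and higher numbers for weaker inhibition), compound 1 gives 62 nM, compound 2 gives 780 nM and compound 3 gives 1250 nM. Compound 3 therefore carries the highest number of the three. Its gap to compound 2 is within the scatter, so the two are not told apart; its gap to compound 1 is beyond the scatter, and compound 1 binds clearly more strongly.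

Compound 4, `NC(=O)Nc1cccc(Cl)c1`, has not yet been measured. It differs from compound 3 in one place: a hydrogen atom in place of a group of 3 heavy atoms (1 carbon, 2 nitrogen; no ring), on an amide-type nitrogen. Going by the values given here, no pair already measured shows this kind of step, so the direction and size must be estimated. All three measured compounds keep a guanidine-type part, and compound 3, the only one without the full biguanide, already stands at the weak end with 1250 nM. Taking away the remaining guanidine is expected to weaken binding further, by a step of a 12-fold higher number from compound 3 to compound 4 (1.08 log units; beyond the scatter), beyond the scatter. Compound 4 is thus expected to give about 15000 nM in this assay, within a range of 3000 nM to 80000 nM.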

Compound 4, inhibition constant: > 10000 nM
Compound 4 ended at the assay's limit; the forecaster's own chance of this, stated with the estimate: 40%; the middle value lies beyond the limit too.
By their numbers in this assay, from the lowest: compound 1; then compounds 2 and 3 (each within the scatter of the next). At a limit, above all of these: compound 4.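

Going by these compounds alone, the replacement on the amide-type nitrogen gives the first measured step: in this assay, a hydrogen atom in place of the group of 3 heavy atoms (1 carbon, 2 nitrogen; no ring) produces an at least 8.0-fold higher number from compound 3 to compound 4 (0.90 log units; beyond the scatter). The earlier compounds shown here formed no one-place pairs, so they could not show that this position matters, and this step shows that binding depends on the group at this position. Compound 4 gives > 10000 nM, which is a limit of the assay and not a number, so the step has a lower bound but no upper one: the limit of > 10000 nM in this assay, at which 1 of the 4 values shown sits.

The compounds shown leave open whether a smaller group on this amide-type nitrogen, such as a methyl or a simple amine, would keep any of the binding that compound 3 shows with 1250 nM. They also leave open whether a longer chain ending in an amine could stand in for the group that leaves, and how far compound 4 actually lies past its limit.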